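Cytotoxicity series: aryl swap on the shared core

The source may hold more compounds than are shown below. What is called first, only, known or untested is meant among the compounds shown, and "the series" means these compounds.

Compound 1 `N#CCCCn1c(Cn2c(=O)n(-c3ccncn3)c3ccncc32)cc2cc(Cl)ccc21`; in an ADME assay on HeLa cells (Homo sapiens) for cytotoxicity, read by ATP content, with a stated time of 3 days (a higher number here means that more compound is tolerated, a lower number that less compound is tolerated), compound 1 gives > 50000 nM, a limit of the assay.
Compound 2 `COc1ccc(-n2c(=O)n(Cc3cc4cc(Cl)ccc4n3CCCC#N)c3cnccc32)c(F)c1`; in this assay compound 2 gives > 50000 nM, a limit of the assay.
Compound 3 `N#CCCCn1c(Cn2c(=O)n(-c3ccc(OC(F)(F)F)cc3)c3ccncc32)cc2cc(Cl)ccc21`; in this assay compound 3 gives > 50000 nM, a limit of the assay.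

Compound 3 thus stands at the limit, as do the two other measured compounds; none of the three can be ranked against another. Compound 4 `N#CCCCn1c(Cn2c(=O)n(-c3ccncc3)c3ccncc32)cc2cc(Cl)ccc21` differs from compound 3 by pyridin-4-yl in place of 4-(trifluoromethoxy)phenyl on an aromatic nitrogen. Among the compounds with values here, the steps that bear on this exchange of the group on the aromatic nitrogen are a step that the two limits leave unreadable from compound 1 to compound 3, a step that the two limits leave unreadable from compound 2 to compound 3 and a step that the two limits leave unreadable from compound 1 to compound 2; all three are unreadable because of the limit of > 50000 nM in this assay, at which 3 of the 3 values shown sit. No readable step exists for any such exchange, so the expected step of a number no higher from compound 3 to compound 4 (the limit leaves the size open) is none that the assay could resolve. Compound 4 is expected to give 50000 nM, with a range of 20000 nM to 50000 nM, most likely again only as a limit.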

Compound 4, half-maximal cytotoxic concentration: > 50000 nM
Compound 4: no number, only a limit; the forecaster's own chance of this, stated with the estimate: 85%; the middle value lies on the limit itself.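

Compound 4 adds no readable step against compound 1, compound 2 or compound 3, because all four values end at a limit: the limit of > 50000 nM in this assay, at which 4 of the 4 values shown sit. The compounds shown leave open whether the group on the aromatic nitrogen changes the tolerated concentration in this assay.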